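Microsomal clearance in a pyridyl amide series: methoxy to aminoalcohol

The compounds below may be only part of what the source reports. "The series", "measured", "known", "first", "only" and "open" are said of these compounds alone.

Compound 2 `COc1ccc(C(=O)Nc2cccc(S(=O)(=O)C3CCCC3)n2)c(N2CCC3(CC2)CC3)c1` carries a methoxy on the core it shares with compound 1 `O=C(Nc1cccc(S(=O)(=O)C2CCCC2)n1)c1ccc(NCCO)cc1N1CCC2(CC1)CC2` and compound 3 `CC(C)(CO)Nc1ccc(C(=O)Nc2cccc(S(=O)(=O)NC3CCCC3)n2)c(N2CCC3(CC2)CC3)c1`. In an ADME assay on microsomes from liver (Mus musculus) for metabolic stability, read by LC-MS, with a stated time of 40 min, tested at 0.5 uM (on this read-out lower numbers stand for slow clearance and higher numbers for fast clearance), compound 2 gives > 399 mL.min-1.g-1, which is a limit of the assay and not a number. Compound 1 gives > 399 mL.min-1.g-1, likewise a limit. Compound 3 gives > 399 mL.min-1.g-1, again a limit. Among the values shown, compound 2 stands where every other value stands: the limit of > 399 mL.min-1.g-1 in this assay, at which 3 of the 3 values shown sit. For the measured compounds named here, the one step between compounds differing in a single place, a step that the two limits leave unreadable from compound 1 to compound 2, has both ends at that limit, so its size is not readable.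

Compound 4 `CC(C)(O)CNc1ccc(C(=O)Nc2cccc(S(=O)(=O)C3CCCC3)n2)c(N2CCC3(CC2)CC3)c1` differs from compound 2 by (2-hydroxy-2-methylpropyl)amino in place of methoxy on an aromatic carbon. Going by the values given here, no measured step with a readable size bears on this change. With compound 1, compound 2 and compound 3 all at the limit, the expectation for compound 4 in this assay is a value that again reaches the limit rather than a step in either direction beyond the scatter. The expected step that the limit leaves unreadable from compound 2 to compound 4 is therefore estimated as none beyond the scatter. Compound 4 is estimated at 450 mL.min-1.g-1, with a range from 200 mL.min-1.g-1 to 900 mL.min-1.g-1.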

Compound 4, intrinsic clearance in microsomes: > 399 mL.min-1.g-1
Compound 4: only a limit was reported (the forecaster's own chance of this, stated with the estimate: 65%); the middle value does not contradict the limit.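

In this assay compound 1, compound 2 and compound 4 all stand at a limit, so neither step to compound 4 can be read: the limit of > 399 mL.min-1.g-1 in this assay, at which 4 of the 4 values shown sit.

The compounds shown leave open whether methoxy, (2-hydroxyethyl)amino and (2-hydroxy-2-methylpropyl)amino differ at all in intrinsic clearance in microsomes; none of them yields a number.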